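The source may hold more compounds than are shown below. What is called first, only, known or untested is meant among the compounds shown, and "the series" means these compounds.

Compound 2, with the structure `COc1cc(C)c(-c2cccc(COc3ccc(OCC(=O)O)c(F)c3)c2)c(C)c1`, stands at the lower end of what has been measured: in a functional assay on CHO cells for agonist activity at Free fatty acid receptor 1 (Homo sapiens), read by FLIPR and calcium flux (on this read-out lower numbers stand for an effect already at smaller amounts and higher numbers for an effect only at larger amounts of compound), compound 2 gives 49.7 nM. Within the data shown here, the only other measured compound is compound 1, with the structure `Cc1cc(O)cc(C)c1-c1cccc(COc2ccc(OCC(=O)O)c(F)c2)c1`, which in this assay gives 110 nM; the single measured step is a 2.2-fold lower number from compound 1 to compound 2 (0.35 log units; beyond the scatter), a methyl in place of hydrogen on an oxygen on an aromatic ring.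

Compound 3, with the structure `COCCOc1cc(C)c(-c2cccc(COc3ccc(OCC(=O)O)c(F)c3)c2)c(C)c1`, differs from compound 2 by methoxymethyl in place of hydrogen on a saturated chain carbon bound to an oxygen on an aromatic ring. Among the measured compounds shown here, no measured step matches this change: the one step in hand, a 2.2-fold lower number from compound 1 to compound 2 (0.35 log units; beyond the scatter), concerns a different group at a different place, so it gives no direct guide. With only that to go on, the expected step of a 1.2-fold lower number from compound 2 to compound 3 (0.09 log units; within the scatter) is small and not clearly beyond the scatter. The value expected for compound 3 in this assay is therefore 40 nM, within a range from 12 nM to 130 nM.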

Compound 3, half-maximal effective concentration: 104 nM
Estimate against measurement, compound 3: 2.6-fold (0.41 log units) below; the measured number falls inside the stated range.
By their numbers in this assay, from the lowest: compound 2; then compounds 3 and 1 (each within the scatter of the next).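

At this oxygen on an aromatic ring, extending the methoxy of compound 2 to the 2-methoxyethoxy of compound 3 does not keep the earlier gain: in this assay this change gives a 2.1-fold higher number from compound 2 to compound 3 (0.32 log units; beyond the scatter) (modest in size). Replacing the hydrogen on the same oxygen with 2-methoxyethyl gives a 1.1-fold lower number from compound 1 to compound 3 (0.02 log units; within the scatter) and so leaves the number level with that of the hydroxyl compound, which means that a small methyl and a longer chain on this oxygen do not give the same result. No measurement here bears on the reason for this difference.

From the compounds shown here alone, whether an ethyl on this oxygen would stay close to compound 2 or to compound 3 remains open. So does the result of a chain ending in an amine or a carboxylic acid at this place.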